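Ortho-substituent swaps on the benzylidene piperidine tail

The source may report more compounds than this note shows. Statements on the series, on what has been measured and on what is new or still open speak of the compounds shown alone.

Going by the values given here, compound 3 `CN(C)CC[C@H](CSc1ccccc1)Nc1ccc(S(=O)(=O)NC(=O)c2ccc(N3CCC(=Cc4ccccc4C#N)CC3)cc2)cc1[N+](=O)[O-]` gives 13 nM in an assay on isolated protein for displacement of a labelled ligand from Apoptosis regulator Bcl-2 (Homo sapiens), read by fluorescence polarization (a higher number here means a weaker inhibitor, a lower number a stronger inhibitor), the highest of the three numbers measured so far. Compound 1 `CN(C)CC[C@H](CSc1ccccc1)Nc1ccc(S(=O)(=O)NC(=O)c2ccc(N3CCC(=Cc4ccccc4Cl)CC3)cc2)cc1[N+](=O)[O-]` gives 0.7 nM, compound 2 `CN(C)CC[C@H](CSc1ccccc1)Nc1ccc(S(=O)(=O)NC(=O)c2ccc(N3CCC(=Cc4ccccc4C(F)(F)F)CC3)cc2)cc1[N+](=O)[O-]` gives 2 nM. The change to compound 4 `CN(C)CC[C@H](CSc1ccccc1)Nc1ccc(S(=O)(=O)NC(=O)c2ccc(N3CCC(=Cc4cccnc4)CC3)cc2)cc1[N+](=O)[O-]` is pyridin-3-yl in place of 2-cyanophenyl on a double-bonded chain carbon bound to a double-bonded ring carbon. Among the compounds with values here, the steps that bear on it both involve the cyano group: a 19-fold higher number from compound 1 to compound 3 (1.27 log units; beyond the scatter) and a 6.5-fold higher number from compound 2 to compound 3 (0.81 log units; beyond the scatter); each replacement of the cyano compound's neighbours by cyano raised the number. Within the data shown here, no measured pair removes the ortho substituent or introduces a ring nitrogen, so the direction rests only on compound 3 being the weakest point in this assay. For compound 4 a modestly lower number is expected, a 2.6-fold lower number from compound 3 to compound 4 (0.41 log units; beyond the scatter), giving an estimate of 5 nM with a range from 1 nM to 30 nM.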

Compound 4, inhibition constant: 68 nM
Compound 4: middle estimate off by 14-fold (1.13 log units), on the low side, outside the stated range (above it).
By their numbers in this assay, from the lowest: compound 1; then compound 2; then compound 3; then compound 4.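

On the double-bonded chain carbon, pyridin-3-yl gives the highest number of the four in this assay with a 5.2-fold higher number from compound 3 to compound 4 (0.72 log units; beyond the scatter) and a 34-fold higher number from compound 2 to compound 4 (1.53 log units; beyond the scatter) and a 97-fold higher number from compound 1 to compound 4 (1.99 log units; beyond the scatter) across the set. Compound 3 therefore no longer marks the weak end of the series, and 2-cyanophenyl, the poorest of the three substituted phenyl groups, still ranks ahead of pyridin-3-yl. This change removes the nitrile and brings in a ring hetero atom together, and the compounds shown do not separate the two; an unsubstituted phenyl or a 2-chloropyridin-3-yl group would. No measurement here explains the loss.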